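A few compounds are considered here, and "the series" means these few. Any claim that something is new, unique, unknown or untested is made for them only; others in the source may bear on it.

In a functional assay on HepG2 cells (Homo sapiens) for inhibition, read by MTT assay, with a stated time of 3 days (a higher number here means a weaker inhibitor, a lower number a stronger inhibitor), compound 1 (`COc1cc(-c2nc3ccccc3s2)ccc1OCC(=O)NNC(=O)CN[C@@H](CS)C(=O)O`) gives 3120 nM and compound 2 (`COc1cc(-c2nc3ccccc3s2)ccc1OCC(=O)NNC(=O)CN[C@@H](CCSC)C(=O)O`) gives 3780 nM, so compound 2 stands level with compound 1 within the scatter. Compound 3 (`CCOC(=O)[C@H](NCC(=O)NNC(=O)COc1ccc(-c2nc3ccccc3s2)cc1OC)[C@@H](C)CC`) is still unmeasured. It carries 1-(ethoxycarbonyl)-2-methylbutyl in place of 1-carboxy-3-(methylsulfanyl)propyl on an amine nitrogen. Among the compounds with values here, the only measured step, a 1.2-fold higher number from compound 1 to compound 2 (0.08 log units; within the scatter), keeps the carboxy group, so it bears only weakly on this change. Within the data shown here, no measured compound carries ethoxycarbonyl, so the range stays wide. The expected step is a 1.3-fold lower number from compound 2 to compound 3 (0.10 log units; within the scatter), with none firmly expected beyond the scatter. For compound 3 the estimated value is 3000 nM, with an expected range of 1000 nM to 9000 nM.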

Compound 3, half-maximal inhibitory concentration: 3970 nM
Estimate against measurement, compound 3: 1.3-fold (0.12 log units) below; the measured number falls inside the stated range.
By their numbers in this assay, from the lowest: compounds 1, 2 and 3 (each within the scatter of the next).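

In this assay, putting 1-(ethoxycarbonyl)-2-methylbutyl on the amine nitrogen gives a 1.1-fold higher number from compound 2 to compound 3 (0.02 log units; within the scatter) and, against the 1-carboxy-2-sulfanylethyl group, a 1.3-fold higher number from compound 1 to compound 3 (0.10 log units; within the scatter). The position therefore reads level with an ethyl ester and no sulfur in the group, whereas the earlier pair varied only the sulfur-bearing chain beside a free carboxy group.

Ester and side chain change together here, so their separate contributions remain open, as does the reading of a group ending in an amine at this nitrogen. No measurement available here offers an explanation for these level numbers.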